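The compounds below may be only part of what the source reports. "The series", "measured", "known", "first", "only" and "open" are said of these compounds alone.

Compound 1 `CCOC(=O)c1cnc(N2CCN(Cc3cccc(C(=O)OC)c3)CC2)nc1Oc1c(C)cc(-c2ccc(C#N)cc2)cc1C` and compound 2 `CCOC(=O)c1cnc(N2CCN(Cc3ccccc3[N+](=O)[O-])CC2)nc1Oc1c(C)cc(-c2ccc(C#N)cc2)cc1C` share one core and were both examined in an ADME assay on MT4 cells (Homo sapiens) for cytotoxicity, read by MTT assay, with a stated time of 4 days; a lower number here means that less compound is tolerated, a higher number that more compound is tolerated. Compound 1 gives > 125000 nM, which is a limit of this assay and not a number. Compound 2 gives >= 78700 nM, likewise a limit. The step that the two limits leave unreadable from compound 1 to compound 2 therefore cannot be read. Compound 3 `CCOC(=O)c1cnc(N2CCN(Cc3ccc(S(N)(=O)=O)cc3)CC2)nc1Oc1c(C)cc(-c2ccc(C#N)cc2)cc1C` carries 4-sulfamoylphenyl in place of 2-nitrophenyl on a saturated chain carbon bound to an amine nitrogen in a ring. Going by the values given here, no measured step offers a readable size, so the change in this assay from compound 2 to compound 3 is expected to be none beyond the scatter, as a step that the limit leaves unreadable from compound 2 to compound 3. Compound 3 is thus estimated at 100000 nM, within 40000 nM to 250000 nM.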

Compound 3, half-maximal cytotoxic concentration: >= 7930 nM
Compound 3 was reported as a limit; the forecaster's own chance of this, stated with the estimate: 80%; the middle value lies beyond the limit too.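

In this assay compound 3 gives >= 7930 nM, a limit and not a number, so the steps linking compound 1, compound 2 and compound 3 cannot be read. From the compounds shown here alone, whether exchanging these groups changes the tolerated concentration at all remains open.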